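A few compounds are considered here, and "the series" means these few. Any claim that something is new, unique, unknown or untested is made for them only; others in the source may bear on it.

Measured so far in a functional assay on MCF7 cells (Homo sapiens) for antiproliferative activity, read by sulforhodamine B assay, with a stated time of 48 h; on this read-out higher numbers stand for weaker inhibition of growth and lower numbers for stronger inhibition of growth:
- compound 1, `CCCCCCCCCCCCCCCCCC(=O)N1CCOCC1`: 42.8 ug/mL
- compound 2, `CCCCCCCCCCCCCCCCCC(=O)N[C@H](C)c1ccccc1`: 0.06 ug/mL

Of these two, compound 1 stands highest at 42.8 ug/mL, which is the weaker growth inhibition. Next in the series is compound 3, `CCCCCCCCCCCCCCCC(=O)N1CCOCC1`. The change is hydrogen in place of ethyl on a saturated chain carbon, ten or more bonds along the chain from a carbonyl carbon. Among the compounds with values here, the single measured step, a 710-fold lower number from compound 1 to compound 2 (2.85 log units; beyond the scatter), is large, but it has (1-phenylethyl)amino in place of morpholin-4-yl on a carbonyl carbon and leaves the chain unchanged. Within the data shown here, no measured step alters the chain, so the data fix no direction. Compound 3 keeps the morpholin-4-yl of compound 1, so no step beyond the scatter is expected in this assay. The expected step is a 1.1-fold lower number from compound 1 to compound 3 (0.05 log units; within the scatter). For compound 3 the estimated value is 38 ug/mL, with an expected range of 14 ug/mL to 100 ug/mL.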

Compound 3, concentration for 50% growth inhibition: 15.4 ug/mL
The estimate for compound 3 lay 2.5-fold (0.39 log units) above the measured number; the measured number falls inside the stated range.
By their numbers in this assay, from the lowest: compound 2; then compound 3; then compound 1.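

In this assay the chain is now shown to matter: with morpholin-4-yl kept on the carbonyl carbon, hydrogen in place of ethyl on a saturated chain carbon, ten or more bonds along the chain from a carbonyl carbon, gives a 2.8-fold lower number from compound 1 to compound 3 (0.44 log units; beyond the scatter) and so stronger inhibition of growth with the shorter chain. This first measured step at this position is modest beside a 710-fold lower number from compound 1 to compound 2 (2.85 log units; beyond the scatter) at the carbonyl carbon, so the chain change so far moves the number far less than the amide change does. No evidence to hand bears on why the number moves with this change.

The compounds shown leave open whether the same chain change holds with (1-phenylethyl)amino in place of morpholin-4-yl. They also leave open how a longer chain, or a chain carrying a carboxylic acid, would read in this assay against compound 1.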